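From Allyl to Cyano: Expected Tolerance of Compound 3

The source may report more compounds than this note shows. Statements on the series, on what has been measured and on what is new or still open speak of the compounds shown alone.

Compound 1 `Cc1cn([C@H]2C[C@H](O)[C@](CO)(N=[N+]=[N-])S2)c(=O)[nH]c1=O` carries an azido group on a saturated ring carbon, and in an ADME assay on MT4 cells (Homo sapiens) for cytotoxicity, read by MTT assay, with a stated time of 4 days (a lower number here means that less compound is tolerated, a higher number that more compound is tolerated), compound 1 gives 40000 nM. Compound 2 `C=CC[C@]1(CO)S[C@@H](n2cc(C)c(=O)[nH]c2=O)C[C@@H]1O` has an allyl group in that place instead. In this assay compound 2 reaches only a limit of the assay, > 100000 nM, so its exact number is not known. The step of an at least 2.5-fold higher number from compound 1 to compound 2 (0.39 log units; beyond the scatter) is thus at least modest, resting on (the limit of > 100000 nM in this assay, at which 1 of the 2 values shown sits). Compound 3 `Cc1cn([C@H]2C[C@H](O)[C@@](C#N)(CO)S2)c(=O)[nH]c1=O` brings the next change: cyano in place of allyl on a saturated ring carbon. Among the measured compounds shown here, the single measured step swaps azido for allyl, not allyl for cyano, so it offers only indirect guidance: moving from azido to allyl raised the number, so moving away from allyl to another group may lower it again. Compound 3 is therefore expected to give about 50000 nM, between 15000 nM and 150000 nM. The expected step is an at least 2.0-fold lower number from compound 2 to compound 3 (0.30 log units; that floor lies within the scatter).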

Compound 3, half-maximal cytotoxic concentration: > 100000 nM
Compound 3 was reported as a limit (the forecaster's own chance of this, stated with the estimate: 40%); middle value at least 2.0-fold (0.30 log units) from the limit.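

In this assay compound 3 gives > 100000 nM, which is a limit of the assay and not a number. Cyano in place of azido gives an at least 2.5-fold higher number from compound 1 to compound 3 (0.39 log units; beyond the scatter), so two different groups on this saturated ring carbon now go with a higher number than azido, the only one of the three with an exact value. The step between the allyl and cyano compounds cannot be read, and the two groups cannot be put in order, as the values shown gather at one limit: the limit of > 100000 nM in this assay, at which 2 of the 3 values shown sit.

From the compounds shown here alone, how much of the allyl or cyano compound is tolerated stays unknown, as does whether the rise comes from losing azido or from the group that replaces it. Going by these compounds, whether an amine, a carboxylic acid or a longer chain on this carbon would also reach the limit stays open.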